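From cyclohexyl to benzyl on the shared core

A few compounds are considered here, and "the series" means these few. Any claim that something is new, unique, unknown or untested is made for them only; others in the source may bear on it.

In a functional assay for inhibition, with Rattus norvegicus as the target (on this read-out lower numbers stand for stronger inhibition and higher numbers for weaker inhibition), compound 1 `N#Cc1ccc(Nc2c(NC3CCCC3)c(=O)c2=O)cc1` gives 11500 nM. Compound 2 `N#Cc1ccc(Nc2c(NC3CCCCC3)c(=O)c2=O)cc1` gives > 30000 nM, which is a limit of the assay and not a number. Compound 3 `N#Cc1ccc(Nc2c(NC3CC4CCC3C4)c(=O)c2=O)cc1` has two entries, > 30000 nM; 3350 nM (2 entries).

Compound 4 `N#Cc1ccc(Nc2c(NCc3ccccc3)c(=O)c2=O)cc1` carries benzyl in place of cyclohexyl on a nitrogen on an aromatic ring. Among the compounds with values here, the one measured step at this place is an at least 2.6-fold higher number from compound 1 to compound 2 (0.41 log units; beyond the scatter). It involves no aromatic ring, so it bears only loosely on this change. A modest move towards a lower number is expected in this assay, and the assay may again report only a limit. The expected step is an at least 1.8-fold lower number from compound 2 to compound 4 (0.27 log units; that floor lies within the scatter). For compound 4 the estimated value is 16000 nM, with an expected range of 5000 nM to 30000 nM.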

Compound 4, half-maximal inhibitory concentration: > 30000 nM
Compound 4 was reported as a limit; the forecaster's own chance of this, stated with the estimate: 45%; middle value at least 1.8-fold (0.27 log units) from the limit.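

In this assay compound 4 gives > 30000 nM, a limit and not a number. Benzyl in place of cyclopentyl on a nitrogen on an aromatic ring gives an at least 2.6-fold higher number from compound 1 to compound 4 (0.41 log units; beyond the scatter), so an aromatic ring at this place does not bring a number lower than that of compound 1. The step between compound 2 and compound 4 cannot be read because both sit at the limit: the limit of > 30000 nM in this assay, at which 2 of the 4 values shown sit.

As far as these compounds go, the true values of compound 2 and compound 4 remain open. Also open, from the compounds shown here alone, is whether phenethyl, or a benzyl carrying a carboxylic acid, would give a readable number here.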